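Swapping the Distal Aryl Group on a Butyl-Linked Triazine

The compounds below may be only part of what the source reports. "The series", "measured", "known", "first", "only" and "open" are said of these compounds alone.

Measured compounds:
Compound 1, `CC1(C)N=C(N)N=C(N)N1c1cccc(OCCCOc2ccc(S(=O)(=O)F)cc2)c1`, 7.96
Compound 2, `CC1(C)N=C(N)N=C(N)N1c1cccc(CCCCc2ccc(Cl)cc2Cl)c1`, 8.03

Both compounds were tested in an assay on isolated protein for inhibition of Dihydrofolate reductase (Mus musculus); on this read-out lower numbers stand for lower potency and higher numbers for higher potency (the scale is a negative logarithm). Compound 1 gives 7.96, and compound 2 gives 8.03. Compound 2 has the higher of these two numbers, but the gap to compound 1 falls inside the usual scatter of this assay, so the two cannot be told apart on these data.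

Compound 3, `CC1(C)N=C(N)N=C(N)N1c1cccc(CCCCc2cccc(S(=O)(=O)F)c2)c1`, is not yet measured. Relative to compound 2 it differs in one place: 3-(fluorosulfonyl)phenyl in place of 2,4-dichlorophenyl on a saturated chain carbon, four bonds along the chain from an aromatic carbon. Among the measured compounds shown here, no measured pair shows this exact change, so the expected effect has to be judged from the fact that compound 2 sits close to compound 1, which also carries a fluorosulfonyl-substituted ring and gives 7.96.

Compound 3 is therefore expected to stay near compound 2, with an estimated step of a number 0.13 log units lower from compound 2 to compound 3 (within the scatter), not beyond the scatter in either direction. The estimate for compound 3 in this assay is 7.9, within a range from 7.3 to 8.5.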

Compound 3, logarithm of the reciprocal of the active concentration, log(1/C): 8.1
The estimate for compound 3 lay 0.20 log units below the measured number, within the range that was stated.
By their numbers in this assay, from the lowest: compounds 1, 2 and 3 (each within the scatter of the next).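

In this assay, the swap of 2,4-dichlorophenyl for 3-(fluorosulfonyl)phenyl at the end of the chain gives a step of a number 0.07 log units higher from compound 2 to compound 3 (within the scatter). Among the compounds shown here, this is the first comparison here that isolates the ring at this place, since compound 1 and compound 2 differ in more than one place, and the read-out does not separate the chlorine-bearing ring from the fluorosulfonyl-bearing ring. Nothing available explains why these two rings give such similar numbers.

For the compounds shown here, this single pair cannot show how widely the result extends, as it covers only two rings. From the compounds shown here alone, whether a phenyl ring carrying a carboxylic acid or an amine would also stay within the scatter remains open, as does the effect of a longer chain.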